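A Methyl Branch on the Amide Side Chain of Compound 3

The source may report more compounds than this note shows. Statements on the series, on what has been measured and on what is new or still open speak of the compounds shown alone.

Three compounds sharing one core were tested in a functional assay on DU-145 cells (Homo sapiens) for cytotoxicity, read by MTT assay, with a stated time of 24 h; a lower number here means a stronger inhibitor, a higher number a weaker inhibitor:
compound 1 `CCNC(=O)Cn1nc(N)c2c(C(F)(F)F)cc(-c3ccccc3)nc21` gives 17900 nM;
compound 2 `CCCNC(=O)Cn1nc(N)c2c(C(F)(F)F)cc(-c3ccccc3)nc21` gives 15500 nM;
compound 3 `Nc1nn(CC(=O)NCC(=O)O)c2nc(-c3ccccc3)cc(C(F)(F)F)c12` gives 18800 nM.

Compound 1 and compound 2 differ in one change, (methyl in place of hydrogen on a saturated chain carbon, two bonds along the chain from an amide-type nitrogen), and this gave a 1.2-fold lower number from compound 1 to compound 2 (0.06 log units; within the scatter). Compound 3 differs from compound 1 by carboxy in place of methyl on a saturated chain carbon bound to an amide-type nitrogen, a step of a 1.1-fold higher number from compound 1 to compound 3 (0.02 log units; within the scatter). Compound 4 `CC(NC(=O)Cn1nc(N)c2c(C(F)(F)F)cc(-c3ccccc3)nc21)C(=O)O` has not been measured; it arises from compound 3 by methyl in place of hydrogen on a saturated chain carbon bound to an amide-type nitrogen and a carbonyl carbon. For the measured compounds named here, this is the same kind of change as the one from compound 1 to compound 2, but the surroundings are not identical: there the carbon sat two bonds along the chain from an amide-type nitrogen, here it is bound to an amide-type nitrogen and a carbonyl carbon. Because the earlier step was within the scatter at a 1.2-fold lower number from compound 1 to compound 2 (0.06 log units; within the scatter), the step expected for compound 4 is a 1.1-fold lower number from compound 3 to compound 4 (0.04 log units; within the scatter). Compound 4 is therefore estimated to give 17000 nM, with a likely range from 9000 nM to 32000 nM.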

Compound 4, half-maximal inhibitory concentration: 22400 nM
Compound 4: the middle estimate sits 1.3-fold (0.12 log units) below what was measured; the range from low to high includes it.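

In this assay, adding the methyl gave a 1.2-fold higher number from compound 3 to compound 4 (0.08 log units; within the scatter), and the wider comparisons with the two side chains that carry no carboxy group gave a 1.4-fold higher number from compound 2 to compound 4 (0.16 log units; within the scatter) and a 1.3-fold higher number from compound 1 to compound 4 (0.10 log units; within the scatter). Set beside the earlier step, the same change shows no detectable difference between the two settings: the same change on two cores in this assay, a 1.2-fold lower number (0.06 log units; within the scatter) from compound 1 to compound 2 and a 1.2-fold higher number (0.08 log units; within the scatter) from compound 3 to compound 4, 1.4-fold (0.14 log units) apart, within the scatter of two such steps. This shows only that the methyl left the number within the scatter in both places; it does not show that a change with a real effect would carry over from one compound pair to another, and a single pair of small steps makes no rule for the series.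

Going by these compounds, it remains open whether an ethyl or a phenyl on this same chain carbon, or an amine in place of the carboxylic acid, would give a step beyond the scatter. A longer chain on the amide nitrogen is a further open case, since propyl is the longest chain shown here.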